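The source may report more compounds than this note shows. Statements on the series, on what has been measured and on what is new or still open speak of the compounds shown alone.

Of the compounds shown here, two have been measured in a functional assay on CCRF-CEM cells (Homo sapiens) for cytotoxicity; a higher number here means that more compound is tolerated, a lower number that less compound is tolerated. Compound 1 `O=C1c2ccccc2N(Cc2ccccc2)S(=O)(=O)N1COCc1ccccc1` gives 100 ug/mL in this assay. Compound 2 `CC(=O)OCCOCN1c2ccccc2C(=O)N(Cc2ccccc2)S1(=O)=O` gives 103 ug/mL in this assay, a number that sits within the scatter of the value of compound 1. Compound 3 `C#CCOCN1c2ccccc2C(=O)N(Cc2ccccc2)S1(=O)=O` has not yet been measured in this assay. It differs from compound 2 in one place: ethynyl in place of acetoxymethyl on a saturated chain carbon bound to an oxygen on a saturated carbon. Going by the values given here, no step between measured compounds is known that bears on this change, and the two measured values lie close together, so the expected step is a 1.0-fold lower number from compound 2 to compound 3 (0.01 log units; within the scatter), none beyond the scatter. Compound 3 is therefore expected to give 100 ug/mL in this assay, within a range from 50 ug/mL to 200 ug/mL.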

Compound 3, half-maximal cytotoxic concentration: 23 ug/mL
For compound 3 the middle estimate is 4.3-fold (0.64 log units) above the measured one; the whole stated range lies above it.
By their numbers in this assay, from the lowest: compound 3; then compounds 1 and 2 (each within the scatter of the next).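

At the saturated chain carbon bound to an oxygen on a saturated carbon, the side chain matters in this assay: ethynyl in place of acetoxymethyl gives a 4.5-fold lower number from compound 2 to compound 3 (0.65 log units; beyond the scatter), so less compound is tolerated. The two earlier values, within the scatter of each other, gave no sign of this sensitivity. Nothing available bears on the cause of this step. On these data alone, it remains open whether the step follows from the entering ethynyl or from the loss of acetoxymethyl. A propyl chain or a hydroxymethyl group at the same place would help separate the two.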